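The compounds below may be only part of what the source reports. "The series", "measured", "known", "first", "only" and "open" are said of these compounds alone.

Compound 3 `Cc1ccc(C2=NN(C(=S)Nc3ccccc3)C(c3ccc4c(c3)OCCO4)C2)cc1` gives 6320 nM in a functional assay on A-375 cells (Homo sapiens) for antiproliferative activity, read by MTT assay, with a stated time of 48 h (a higher number here means a weaker inhibitor of growth, a lower number a stronger inhibitor of growth), the second highest of the three numbers measured; compound 2 `S=C(Nc1ccccc1)N1N=C(c2ccc(Br)cc2)CC1c1ccc2c(c1)OCCO2` gives 470 nM and compound 1 `S=C(Nc1ccccc1)N1N=C(c2ccc(Cl)cc2)CC1c1ccc2c(c1)OCCO2` gives 195000 nM. Compound 4 `FC(F)(F)c1ccc(C2=NN(C(=S)Nc3ccccc3)C(c3ccc4c(c3)OCCO4)C2)cc1` differs from compound 3 by trifluoromethyl in place of methyl on an aromatic carbon. The measured steps at this aromatic carbon are all large and uneven: a 31-fold lower number from compound 1 to compound 3 (1.49 log units; beyond the scatter), a 13-fold higher number from compound 2 to compound 3 (1.13 log units; beyond the scatter), and a 410-fold lower number from compound 1 to compound 2 (2.62 log units; beyond the scatter). Going by the values given here, none of them involves trifluoromethyl, so they show only that exchanges at this carbon move the number a great deal, not in which direction the new exchange will go. Compound 4 is therefore expected to give about 3000 nM in this assay, with a wide range from 300 nM to 30000 nM. That estimate means a 2.1-fold lower number from compound 3 to compound 4 (0.32 log units; beyond the scatter).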

Compound 4, concentration for 50% growth inhibition: 43500 nM
Compound 4: middle estimate off by 15-fold (1.16 log units), on the low side; measured number outside the range, above it.
By their numbers in this assay, from the lowest: compound 2; then compound 3; then compound 4; then compound 1.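

In this assay, trifluoromethyl at this aromatic carbon gives a weaker result than methyl or bromo, with a 6.9-fold higher number from compound 3 to compound 4 (0.84 log units; beyond the scatter) and a 93-fold higher number from compound 2 to compound 4 (1.97 log units; beyond the scatter). It still improves on chloro, with a 4.5-fold lower number from compound 1 to compound 4 (0.65 log units; beyond the scatter). The four groups therefore rank bromo, methyl, trifluoromethyl, chloro from the lowest number, with the two halogens at opposite ends and trifluoromethyl and methyl between them.

No evidence shown accounts for this order. Where a methoxy group, an amine or a nitrile at this carbon would fall in the order remains open.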